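The source may report more compounds than this note shows. Statements on the series, on what has been measured and on what is new or still open speak of the compounds shown alone.

Compound 1 `COc1cc2ncnc(Nc3ccccc3)c2cc1OCCCCC(=O)Nc1ccc(S(N)(=O)=O)cc1` in a functional assay on A549 cells (Homo sapiens) for antiproliferative activity, read by MTT assay, with a stated time of 72 h; a higher number here means a weaker inhibitor, a lower number a stronger inhibitor: > 40000 nM, which is a limit of the assay rather than a number.
Compound 2 `C#Cc1cccc(Nc2ncnc3ccc(NC(=S)Nc4ccc(S(N)(=O)=O)cc4)cc23)c1` in this assay: > 40000 nM, likewise only a limit.

Compound 2 therefore stands where both measured values sit, at the limit of > 40000 nM in this assay, at which 2 of the 2 values shown sit; no numerical potency is known for it. Compound 3 `NS(=O)(=O)c1ccc(NC(=S)Nc2ccc3ncnc(Nc4ccc(C(F)(F)F)cc4)c3c2)cc1` differs from compound 2 by 4-(trifluoromethyl)phenyl in place of 3-ethynylphenyl on a nitrogen on an aromatic ring. For the measured compounds named here, no step between measured compounds is known here, so there is no measured guide to the size of this change. Compound 2 sitting at its limit, compound 3 is expected to remain near that limit as well, an expected step that the limit leaves unreadable from compound 2 to compound 3, none beyond the scatter. Compound 3 is thus estimated at 60000 nM, within 12000 nM to 300000 nM.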

Compound 3, half-maximal inhibitory concentration: > 40000 nM
Compound 3 was reported as a limit; the forecaster's own chance of this, stated with the estimate: 75%; the middle value lies beyond the limit too.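

Compound 2 and compound 3 are both reported only as limits in this assay, so no step can be read between them. The compounds shown leave open which change, if any, would bring a measurable potency: the limit of > 40000 nM in this assay, at which 3 of the 3 values shown sit.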